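The source may report more compounds than this note shows. Statements on the series, on what has been measured and on what is new or still open speak of the compounds shown alone.

Measured so far: compound 1 `N#Cc1c(N2CCCCC2)c2sc3ccccc3c2n2c1nc1ccccc12`, compound 2 `CC(C)CNc1ccc2c(c1)sc1cc(C#N)c3nc4ccccc4n3c12` and compound 3 `CC(C)CNc1c(C#N)c2nc3ccccc3n2c2c1sc1ccccc12`. In a physicochemical assay for lipophilicity, read by HPLC, at pH 2.7 (on this read-out higher numbers stand for higher lipophilicity and lower numbers for lower lipophilicity), compound 1 gives 7.7, compound 2 gives 7.76 and compound 3 gives 4.67. Compound 4 `N#Cc1cc2sc3cc(N4CCCCC4)ccc3c2n2c1nc1ccccc12` is not yet measured.

From compound 3 to compound 1 the change is piperidin-1-yl in place of isobutylamino on an aromatic carbon, and it made a number 3.03 log units higher from compound 3 to compound 1 (beyond the scatter). From compound 2 to compound 4 the change is piperidin-1-yl in place of isobutylamino on an aromatic carbon. The places differ: in compound 3 the ring has one nitrogen and the group is ortho to a cyano group, in compound 2 the ring is of carbon only, meta to a fused ring and para to a fused ring. It is the same kind of change, not the same. How the core of compound 2 differs from that of compound 3 is not broken down here.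

The step of a number 0.24 log units higher from compound 2 to compound 4 (within the scatter) is expected to be much smaller than the earlier one, because compound 2 already gives 7.76, within the scatter of compound 1 at 7.7. Compound 4 is expected at 8, between 7.3 and 8.9.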

Compound 4, distribution coefficient: 8.52
Estimate against measurement, compound 4: 0.52 log units below; measured number inside the range.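

In this assay, putting piperidin-1-yl in place of isobutylamino gives a number 3.03 log units higher from compound 3 to compound 1 (beyond the scatter) on one core and a number 0.76 log units higher from compound 2 to compound 4 (beyond the scatter) on the other, so the number rises both times, but the size of the rise does not carry over from one core to the other. Two pairs show only that the direction matched in these compounds, and they set no rule for the series. Nothing available here explains why the two steps differ in size.

The compounds shown leave open whether a third core would give the same direction. They also leave open how another amine, such as morpholine or a longer chain like hexylamino, would compare on these two cores.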